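The source may hold more compounds than are shown below. What is called first, only, known or untested is meant among the compounds shown, and "the series" means these compounds.

Compound 1 `CCC(c1ccccc1)c1nc(-c2ccc(Cl)cc2)c(CC(=O)O)s1` is the starting point. In an in vitro assay on HEK385-7 cells for displacement of a labelled ligand from prostaglandin D2 receptor 2 (Homo sapiens) (on this read-out higher numbers stand for weaker inhibition and lower numbers for stronger inhibition), compound 1 gives 190 nM, the lowest of the two numbers in hand. Compound 2 `Cc1cc(-c2nc(C(c3ccc(F)cc3)c3ccc(F)cc3)sc2CC(=O)O)cnc1N` gives 880 nM in this assay, a gap from compound 1 that lies beyond the usual scatter; since these two compounds differ in more than one place, the gap offers no clean guide. Compound 3 `COc1ccc(C(c2ccccc2)c2nc(-c3ccc(Cl)cc3)c(CC(=O)O)s2)cc1` differs from compound 1 in a single place: 4-methoxyphenyl in place of ethyl on a saturated chain carbon bound to two aromatic carbons. Going by the values given here, no measured pair shows this change, so the expected step, a 1.3-fold higher number from compound 1 to compound 3 (0.12 log units; within the scatter), is a small rise within the scatter. Compound 3 is estimated at 250 nM, with a range from 80 nM to 800 nM.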

Compound 3, half-maximal inhibitory concentration: 8.4 nM
Compound 3: the middle estimate sits 30-fold (1.47 log units) above what was measured; measured number outside the range, below it.
By their numbers in this assay, from the lowest: compound 3; then compound 1; then compound 2.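

Replacing ethyl with 4-methoxyphenyl on a saturated chain carbon bound to two aromatic carbons gives a 23-fold lower number from compound 1 to compound 3 (1.35 log units; beyond the scatter) in this assay and shows that this position strongly affects the read-out. The larger group with its aromatic ring is clearly tolerated here and goes with much stronger inhibition. No measurement in hand explains this gain.

Plain phenyl at this carbon would help show whether the gain needs the methoxy group or only the ring. Also open, going by these compounds, is how 4-hydroxyphenyl or an amine would compare here.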